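The source may report more compounds than this note shows. Statements on the series, on what has been measured and on what is new or still open speak of the compounds shown alone.

Compound 2, `Cc1ccsc1C(=CCCN(C)C(CCO)C(=O)NCc1ccc(Cl)cc1)c1sccc1C`, is one of two compounds with a measured number in a physicochemical assay for lipophilicity, read by HPLC; a lower number here means a more polar compound, a higher number a more lipophilic compound. In this assay compound 2 gives 6.38. For the measured compounds named here, the only other measured compound, compound 1, `Cc1ccsc1C(=CCCN(C)C(CCN)C(=O)NCc1ccccc1Cl)c1sccc1C`, gives 6.11 in this assay; the two numbers lie within the usual scatter of each other, so nothing separates them, and no step between them is worked out here. Compound 3, `Cc1ccsc1C(=CCCN(C)C(CCO)C(=O)NCc1ccccc1Cl)c1sccc1C`, has not yet been measured in this assay. It differs from compound 2 in one place: 2-chlorophenyl in place of 4-chlorophenyl on a saturated chain carbon bound to an amide-type nitrogen. The same atoms are present in both, joined differently. Going by the values given here, with no measured step of this kind to go by, the author expects the move from compound 2 to compound 3 to shift this assay by no more than the scatter, with a small downward lean estimated as a number 0.08 log units lower from compound 2 to compound 3 (within the scatter). For compound 3 the author therefore estimates 6.3, within a range from 6 to 6.6.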

Compound 3, partition coefficient: 6.23
Estimate against measurement, compound 3: 0.07 log units above; the measured number falls inside the stated range.
By their numbers in this assay, from the lowest: compounds 1, 3 and 2 (each within the scatter of the next).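

The first step read at this position, 2-chlorophenyl in place of 4-chlorophenyl on a saturated chain carbon bound to an amide-type nitrogen, is a number 0.15 log units lower from compound 2 to compound 3 (within the scatter) in this assay and so gives this change no size that can be told from the scatter. The result also gives a second pair that differs in one place, hydroxy in place of amino on a saturated chain carbon, and that step, a number 0.12 log units higher from compound 1 to compound 3 (within the scatter) in this assay, likewise cannot be told from the scatter. Nothing available bears on why either step has the size it has.

As far as these compounds go, whether an unsubstituted phenyl or a pyridine ring on the benzyl carbon would step beyond the scatter remains open. So does the outcome of a carboxylic acid or a methoxy group in place of the hydroxy.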